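The source may hold more compounds than are shown below. What is called first, only, known or untested is meant among the compounds shown, and "the series" means these compounds.

Working notes on the series at a functional assay on muscle tissue for agonist activity at histamine H2 receptor (Cavia porcellus); on this read-out higher numbers stand for larger maximal responses and lower numbers for smaller maximal responses.

Three compounds have numbers. Compound 1 `Cc1ccc(C(CC/N=C(\N)NCCCc2c[nH]cn2)c2ccccn2)cc1` gives 1. Compound 2 `COc1ccc(C(CC/N=C(\N)NCCCc2c[nH]cn2)c2ccccn2)cc1` gives 0.5. Compound 3 `N=C(NCCCc1c[nH]cn1)NCCC(c1ccc(F)cc1)c1ccccn1` gives 0.8. For the measured compounds named here, the one single-point step with both ends measured is a number 0.50 lower from compound 1 to compound 2 (beyond the scatter), a shift beyond the scatter. Compound 3 stands second of the three: its number is beyond the scatter below that of compound 1 and beyond the scatter above that of compound 2.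

Compound 4 `N=C(NCCCc1c[nH]cn1)NCCC(c1ccc(Br)cc1)c1ccccn1` is not yet measured. The change from compound 3 is bromo in place of fluoro on an aromatic carbon, a halogen exchange on an aromatic carbon of a six-membered aromatic ring of carbon only, para to a large group. Going by the values given here, no measured pair exchanges one halogen for another, so the only step available, from methyl to methoxy at the same place, does not bear directly on this change; it shows only that substitution at this position can move the read-out by a large amount.

With nothing closer to lean on, the number for compound 4 is expected to stay near that of compound 3, a step of no change at the digits printed from compound 3 to compound 4 (within the scatter), within the scatter. The estimate for compound 4 is 0.8, with a range from 0.5 to 1 to allow for an unmeasured exchange.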

Compound 4, intrinsic activity: the largest response reached, as a fraction of the reference agonist's: 0.4
Beside the measured number, compound 4's estimate is 0.40 above it; measured number outside the range, below it.
By their numbers in this assay, from the lowest: compounds 4 and 2 (each within the scatter of the next); then compound 3; then compound 1.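

In this assay a halogen exchange alone proves to be a large change at this place, with a number 0.40 lower from compound 3 to compound 4 (beyond the scatter) on an aromatic carbon para to a large group. The earlier step from methyl to methoxy showed that this position responds to substitution, whereas this step shows that the maximal response also separates two halogens, groups that match in every count computed for them and differ only in the element. Across the series, the values run from compound 1 at 1 to compound 3 at 0.8, then to compound 2 at 0.5 and compound 4 at 0.4, and these last two lie within the scatter of each other, so a 4-bromophenyl and a methoxy-bearing ring give no distinguishable maximal response here.

No measurement bearing on the reason for the step from fluoro to bromo is at hand. The compounds shown also leave open where chloro or iodo would fall relative to fluoro and bromo, and how an amine or a carboxylic acid at the same place would read.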